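A phenyl swap on a shared core

The source may report more compounds than this note shows. Statements on the series, on what has been measured and on what is new or still open speak of the compounds shown alone.

Three compounds that share one core and differ only in a substituted phenyl group have been measured in a functional assay on KB cells (Homo sapiens) for antiproliferative activity, read by sulforhodamine B assay, with a stated time of 3 days; on this read-out higher numbers stand for an effect only at larger amounts of compound and lower numbers for an effect already at smaller amounts. Compound 1 `CCC1=C(O)c2c(oc(-c3ccc(COC)cc3)cc2=O)C(CC)(CC)C1=O` gives > 52.4 uM, which is a limit of the assay and not a number. Compound 2 `CCC1=C(O)c2c(oc(-c3ccccc3C)cc2=O)C(CC)(CC)C1=O` gives 40.9 uM, and compound 3 `CCC1=C(O)c2c(oc(-c3ccc(C)c(F)c3)cc2=O)C(CC)(CC)C1=O` gives 28.1 uM. These last two values stand level, the measured gap being a 1.5-fold lower number from compound 2 to compound 3 (0.16 log units; within the scatter).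

The next structure, compound 4 `CCC1=C(O)c2c(oc(-c3ccc(OC)c(C)c3)cc2=O)C(CC)(CC)C1=O`, carries 4-methoxy-3-methylphenyl in place of 3-fluoro-4-methylphenyl on an aromatic carbon. Going by the values given here, no measured step makes this exact swap, but all three exchange one phenyl group for another at this same place. Besides the gap above, they are an at least 1.2-fold lower number from compound 1 to compound 2 (0.10 log units; that floor lies within the scatter) and an at least 1.8-fold lower number from compound 1 to compound 3 (0.27 log units; that floor lies within the scatter). None of them is shown to go beyond the scatter, so a similar swap is expected to give a small step at most. Compound 4 shares an oxygen in this group only with compound 1, whose reading is > 52.4 uM, so the expectation leans slightly towards a higher number. The expected step is a 1.3-fold higher number from compound 3 to compound 4 (0.11 log units; within the scatter), which remains an estimate. Compound 4 is estimated to give 36 uM, with an expected range from 17 uM to 70 uM.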

Compound 4, concentration for half-maximal effect: 28.5 uM
Compound 4: middle estimate off by 1.3-fold (0.10 log units), on the high side; the measured number falls inside the stated range.
By their numbers in this assay, from the lowest: compounds 3, 4 and 2 (each within the scatter of the next). At a limit, above all of these: compound 1.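

Compound 4 shows that a phenyl group carrying an oxygen can sit level with the oxygen-free groups at this place in this assay, with a 1.0-fold higher number from compound 3 to compound 4 (0.01 log units; within the scatter) and a 1.4-fold lower number from compound 2 to compound 4 (0.16 log units; within the scatter). Going by these compounds alone, the oxygen and the hydrogen-bond acceptor counted in 4-methoxy-3-methylphenyl therefore do not, on their own, set a compound apart here, and the earlier compounds could not show this, as the only group with an oxygen among them gave no number. The comparison with that compound yields only a floor, an at least 1.8-fold lower number from compound 1 to compound 4 (0.26 log units; that floor lies within the scatter), so these two oxygen-bearing groups are not shown to differ, and this comparison rests on a limit of the assay and not on a number: the limit of > 52.4 uM in this assay, at which 1 of the 4 values shown sits.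

Within the data shown here, no step between two measured numbers in this set goes beyond the scatter, so how strongly this position can respond at all remains unknown. From the compounds shown here alone, it also stays open whether an amine or a carboxylic acid on this phenyl group, or a longer chain in place of the methoxy group, would give a clearly different number.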